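The compounds below may be only part of what the source reports. "The series", "measured", "known", "first", "only" and "open" are said of these compounds alone.

Measured so far:
compound 1 `C/C(=N\NC(=O)COc1cccc2ccccc12)c1ccc(O)cc1` — 4.44
compound 2 `C/C(=N\NC(=O)COc1cccc2ccccc12)c1ccccc1O` — 3.08

In a physicochemical assay for lipophilicity, measured as octanol-water partition (a higher number here means a more lipophilic compound, a lower number a more polar compound), compound 2 gives the lower of the two numbers; compound 1 sits higher by a number 1.36 log units lower from compound 1 to compound 2 (beyond the scatter). Compound 3 `C/C(=N\NC(=O)COc1cccc2ccccc12)c1ccc(Br)cc1` carries the change (4-bromophenyl in place of 2-hydroxyphenyl on a carbon with a double bond to nitrogen). Among the compounds with values here, no measured step exchanges a hydroxyl for a bromine, so the single step between compound 1 and compound 2 is only a loose guide: it shows the 4-substituted pattern of compound 1 at 4.44. Compound 3 is therefore expected to rise by a number 2.62 log units higher from compound 2 to compound 3 (beyond the scatter) in this assay. The estimate for compound 3 is 5.7, with a range from 4.9 to 6.5.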

Compound 3, partition coefficient: 3.61
Estimate against measurement, compound 3: 2.09 log units above, outside the stated range (below it).
By their numbers in this assay, from the lowest: compound 2; then compound 3; then compound 1.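

In this assay, 4-bromophenyl in place of 2-hydroxyphenyl gives a number 0.53 log units higher from compound 2 to compound 3 (beyond the scatter), so this position responds to a swap of both group and substitution pattern, though only modestly. Bromo in place of hydroxy on an aromatic carbon gives a number 0.83 log units lower from compound 1 to compound 3 (beyond the scatter), so with the pattern held at 4-substituted, the hydroxy compound keeps the higher number. Nothing measured here offers a reason for this order.

Still open, as far as these compounds go, is how an amine or a carboxylic acid in the same 4-substituted pattern would compare with 4-bromophenyl. Also open, from the compounds shown here alone, is whether a bromine in the 2-substituted pattern would give a number near that of 2-hydroxyphenyl.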